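This account rests on a few compounds, and the source may have more. Where it says the series, first, only, none or still open, it means among the compounds named here.

Series notes, three-membered ring substituent.

Among the measured compounds shown here, compound 3 `CC[C@H](C)[C@H](N)CN(C(=O)[C@@H]1C[C@H]1c1ncccn1)c1ccc(-c2ccccc2)cc1` gives 130 nM in a functional assay for agonist activity at G protein-coupled receptor 88 (Homo sapiens), read by HTRF and cAMP accumulation (on this read-out higher numbers stand for an effect only at larger amounts of compound and lower numbers for an effect already at smaller amounts), and stands lowest of the three numbers so far. Compound 1 `CC[C@H](C)[C@H](N)CN(C(=O)[C@@H]1C[C@H]1c1cccc(F)c1)c1ccc(-c2ccccc2)cc1` gives 560 nM in this assay; compound 2 `CC[C@H](C)[C@H](N)CN(C(=O)[C@@H]1C[C@H]1c1ccccc1F)c1ccc(-c2ccccc2)cc1` gives 650 nM. The two fluorophenyl compounds sit together: a 1.2-fold higher number from compound 1 to compound 2 (0.06 log units; within the scatter). Exchanging either fluorophenyl for the six-membered two-nitrogen ring lowers the number modestly, a 4.3-fold lower number from compound 1 to compound 3 (0.63 log units; beyond the scatter) and a 5.0-fold lower number from compound 2 to compound 3 (0.70 log units; beyond the scatter).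

Compound 4 `CC[C@H](C)[C@H](N)CN(C(=O)[C@@H]1C[C@H]1c1ccoc1)c1ccc(-c2ccccc2)cc1` is not yet measured. It differs from compound 3 in one place: furan-3-yl in place of pyrimidin-2-yl on a saturated ring carbon. For the measured compounds named here, no measured step tests a five-membered ring at this carbon, so the expectation rests only on the three numbers above. The change removes the one ring that gave the lowest number and installs one with a single hetero atom, nearer in kind to the fluorophenyl groups than to pyrimidin-2-yl. The number for compound 4 is therefore expected to rise from that of compound 3, probably by a step beyond the scatter, toward the fluorophenyl level, a 2.3-fold higher number from compound 3 to compound 4 (0.36 log units; beyond the scatter). Compound 4 is estimated at 300 nM, with a range of 120 nM to 800 nM, in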

Compound 4, half-maximal effective concentration: 580 nM
For compound 4 the middle estimate is 1.9-fold (0.29 log units) below the measured one; measured number inside the range.
By their numbers in this assay, from the lowest: compound 3; then compounds 1, 4 and 2 (each within the scatter of the next).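

Working notes on the ring at this carbon. In this assay, replacing pyrimidin-2-yl with furan-3-yl gives up the lower number (a 4.5-fold higher number from compound 3 to compound 4 (0.65 log units; beyond the scatter)), so this position does respond to the ring it carries, and the response is not confined to a comparison with fluorophenyl groups. The five-membered ring with its one oxygen cannot be told apart from either fluorophenyl group (a 1.0-fold higher number from compound 1 to compound 4 (0.02 log units; within the scatter); a 1.1-fold lower number from compound 2 to compound 4 (0.05 log units; within the scatter); both within the scatter), so neither the change from a six-membered to a five-membered ring nor a single ring hetero atom by itself shifts the number among these three compounds. Of the four groups, pyrimidin-2-yl alone stands apart, and no measurement at hand accounts for that difference.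

Still open, from the compounds shown here alone, is whether the lower number needs both ring nitrogens of pyrimidin-2-yl, which pyridin-2-yl would test, and whether their placing counts, which pyrimidin-5-yl would test. Also open, going by these compounds, is whether a nitrogen-bearing five-membered ring such as oxazol-2-yl or pyrazol-1-yl at this carbon falls with furan-3-yl or with pyrimidin-2-yl.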